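The compounds below may be only part of what the source reports. "The series", "measured", "known", "first", "only" and "open" are said of these compounds alone.

Measured compounds:
compound 1 `O=C(c1ccc(CN2C(=O)c3ccccc3C2=O)cc1)N1CCCCC1`: in a functional assay on RAW264.7 cells (Mus musculus) for inhibition (a lower number here means a stronger inhibitor, a higher number a weaker inhibitor), compound 1 gives > 100000 nM; this is a limit of the assay, not a number.
compound 2 `CC(C)(C)OC(=O)N(Cc1ccco1)C(=O)c1ccc(CN2C(=O)c3ccccc3C2=O)cc1`: in this assay compound 2 gives 3450 nM.

For the measured compounds named here, compound 2 thus holds the only number; the one other value sits at the limit of > 100000 nM in this assay, at which 1 of the 2 values shown sits, so no measured step is available against which compound 2 can be placed.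

Compound 3 `O=C(NCc1ccco1)c1ccc(CN2C(=O)c3ccccc3C2=O)cc1` differs from compound 2 by hydrogen in place of tert-butoxycarbonyl on an amide-type nitrogen. Going by the values given here, no pair of measured compounds shows the effect of such a change, and the two values shown say nothing about it. The step from compound 2 to compound 3 is therefore expected to be small, a 1.4-fold higher number from compound 2 to compound 3 (0.16 log units; within the scatter), with no clear direction beyond the scatter. Compound 3 is accordingly estimated at 5000 nM in this assay, with a wide range from 800 nM to 40000 nM.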

Compound 3, half-maximal inhibitory concentration: 56000 nM
The estimate for compound 3 lay 11-fold (1.05 log units) below the measured number; the whole stated range lies below it.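

In this assay the amide-type nitrogen proves to be a sensitive place: hydrogen in place of tert-butoxycarbonyl gives a 16-fold higher number from compound 2 to compound 3 (1.21 log units; beyond the scatter), so the number of compound 2 rests on that group and not on the ((furan-2-yl)methyl)amino part alone. ((furan-2-yl)methyl)amino in place of piperidin-1-yl on a carbonyl carbon gives an at least 1.7-fold lower number from compound 1 to compound 3 (0.25 log units; that floor lies within the scatter), and that floor does not separate the two compounds. The entry for compound 1 is a limit of the assay and not a number: the limit of > 100000 nM in this assay, at which 1 of the 3 values shown sits.

On these data alone, whether a smaller group on this nitrogen, such as acetyl or methoxycarbonyl, would hold the number of compound 2 remains open. Also open, as far as these compounds go, is whether a phenyl ring could stand in place of the furan-2-yl ring with tert-butoxycarbonyl kept on the nitrogen.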